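Swapping trifluoromethyl for bromo on a cyclen-free macrocycle

The compounds below may be only part of what the source reports. "The series", "measured", "known", "first", "only" and "open" are said of these compounds alone.

Measured compounds:
compound 1, `c1ccc2cc(C3CNCCNCCNCCN3)ccc2c1` — > 200000 nM
compound 2, `FC(F)(F)c1ccc(C2CNCCNCCNCCN2)cc1` — 73000 nM

In an ADME assay on HEK293 cells (Homo sapiens) for cytotoxicity (a higher number here means that more compound is needed for the effect, a lower number that less compound is needed), compound 1 reaches only a limit of the assay, > 200000 nM. In this assay, going by the values given here, compound 2 gives 73000 nM, the only real number in this set. The result of compound 1 is a limit of the assay, as shown by the limit of > 200000 nM in this assay, at which 1 of the 2 values shown sits. Compound 3, `Brc1ccc(C2CNCCNCCNCCN2)cc1`, is not yet measured in this assay. Compared with compound 2 it carries bromo in place of trifluoromethyl on an aromatic carbon. Among the compounds with values here, no measured pair in this set differs in this way, so no step of that kind is known. Between compound 2 and compound 3 a step no larger than the usual scatter is expected in this assay, in no firm direction. For compound 3 the expected value in this assay is 90000 nM, within 35000 nM to 200000 nM, which is an expected step of a 1.2-fold higher number from compound 2 to compound 3 (0.09 log units; within the scatter).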

Compound 3, half-maximal effective concentration: > 200000 nM
Compound 3: a limit, no number; the forecaster's own chance of this, stated with the estimate: 30%; middle value at least 2.2-fold (0.34 log units) away from the limit.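

In this assay, going by these compounds alone, the change to bromo gives an at least 2.7-fold higher number from compound 2 to compound 3 (0.43 log units; beyond the scatter) and so supplies the first measured step at this place, on an aromatic carbon para to a large group. It shows that replacing trifluoromethyl with bromo on the shared core, a single change at this position, is enough to carry the result beyond the scatter. The result of compound 3 is a limit and not a number, so the full size of the step cannot be read: the limit of > 200000 nM in this assay, at which 2 of the 3 values shown sit.

The compounds shown leave open whether a different group at this place, such as an amine, a carboxylic acid or a methoxy group, would stay close to compound 2 or also reach the limit. They also leave open whether chloro would behave as bromo does here.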